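Swapping phenyl for cyclohexyl on compound 2

This account rests on a few compounds, and the source may have more. Where it says the series, first, only, none or still open, it means among the compounds named here.

Compound 1 `O=C(NCc1cc(Cl)ccc1-n1cnnn1)[C@@H]1C[C@@H]2C[C@@H]2N1C(=O)[C@H](O)c1cccc(Cl)c1` gives > 500 mL.min-1.g-1
Compound 2 `O=C(NCc1cc(Cl)ccc1-n1cnnn1)[C@@H]1CC=NN1C(=O)[C@H](O)c1ccccc1` gives < 12 mL.min-1.g-1

Both entries are limits of an ADME assay on liver for metabolic stability, with Liver microsome (Homo sapiens) as the target, read by LC-MS, using microsomes (on this read-out higher numbers stand for fast clearance and lower numbers for slow clearance), and not numbers. Compound 2 gives < 12 mL.min-1.g-1 as a limit, so it holds the slow-clearance end of the two compounds shown, without a number of its own.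

Compound 3 `O=C(NCc1cc(Cl)ccc1-n1cnnn1)[C@@H]1CC=NN1C(=O)[C@H](O)C1CCCCC1` carries cyclohexyl in place of phenyl on a saturated chain carbon bound to a carbonyl carbon and an oxygen on a saturated carbon. The change counts as cyclohexyl in place of phenyl on a saturated chain carbon bound to a carbonyl carbon and an oxygen on a saturated carbon and is the only one. Among the measured compounds shown here, no measured pair tests this change, so the expectation remains loose. The expected step of an at least 3.3-fold higher number from compound 2 to compound 3 (0.52 log units; beyond the scatter) is a rise toward faster clearance, beyond the scatter. For this assay compound 3 is estimated at 40 mL.min-1.g-1 as the middle of an expected range from 12 mL.min-1.g-1 to 150 mL.min-1.g-1 in all.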

Compound 3, intrinsic clearance in microsomes: 63 mL.min-1.g-1
Beside the measured number, compound 3's estimate is 1.6-fold (0.20 log units) below it; the range from low to high includes it.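

Cyclohexyl in place of phenyl on a saturated chain carbon bound to a carbonyl carbon and an oxygen on a saturated carbon gives an at least 5.2-fold higher number from compound 2 to compound 3 (0.72 log units; beyond the scatter) in this assay, a rise toward faster clearance. Among the compounds shown here, this is the first reading of a single change at this position, and compound 3 holds the first actual number of the set, since the entries for compound 1 and compound 2 are limits. The full size of the step stays unknown because compound 2 is held only at a limit: the limit of < 12 mL.min-1.g-1 in this assay, at which 1 of the 3 values shown sits.

The step rests on one pair on one core, so it cannot say whether it extends to other cores. It also leaves open where a smaller ring such as cyclopropyl, or a piperidine, would fall relative to compound 2 and compound 3.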